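Replacing a Tetrahydronaphthalene Amide with an Indole Amide

A few compounds are considered here, and "the series" means these few. Any claim that something is new, unique, unknown or untested is made for them only; others in the source may bear on it.

Compound 3 `CN1[C@@H]2c3[nH]c4ccccc4c3C[C@H]1[C@H](C#N)N1[C@@H](CNC(=O)c3cccc4c3CCCC4)c3[nH]c4ccccc4c3C[C@@H]21` gives 4210 nM in a functional assay on HCT-116 cells (Homo sapiens) for cytotoxicity, read by MTT assay, with a stated time of 72 h (a lower number here means a stronger inhibitor, a higher number a weaker inhibitor), the highest number among the three measured compounds. Compound 1 `COc1ccc(C(=O)NC[C@H]2c3[nH]c4ccccc4c3C[C@H]3[C@H]4c5[nH]c6ccccc6c5C[C@@H]([C@H](C#N)N23)N4C)cc1` gives 430 nM and compound 2 `CN1[C@@H]2c3[nH]c4ccccc4c3C[C@H]1[C@H](C#N)N1[C@@H](CNC(=O)c3ccc(F)cc3)c3[nH]c4ccccc4c3C[C@@H]21` gives 140 nM. Compound 4 `CN1[C@@H]2c3[nH]c4ccccc4c3C[C@H]1[C@H](C#N)N1[C@@H](CNC(=O)c3cc4ccccc4[nH]3)c3[nH]c4ccccc4c3C[C@@H]21` differs from compound 3 in one place: 1H-indol-2-yl in place of 1,2,3,4-tetrahydronaphthalen-5-yl on a carbonyl carbon. Among the measured compounds shown here, no measured step makes this exact exchange. For the measured compounds named here, the steps that bear on it are a 9.8-fold higher number from compound 1 to compound 3 (0.99 log units; beyond the scatter) and a 30-fold higher number from compound 2 to compound 3 (1.48 log units; beyond the scatter), both showing that the tetrahydronaphthalenyl amide of compound 3 sits far weaker than the phenyl amides. Since the indolyl group is again a flat bicyclic aromatic amide, a modest move back toward the lower numbers is expected, estimated as a 4.7-fold lower number from compound 3 to compound 4 (0.67 log units; beyond the scatter). Compound 4 is therefore expected to give about 900 nM, within 250 nM to 3500 nM.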

Compound 4, half-maximal inhibitory concentration: 880 nM
Compound 4: the middle estimate sits 1.0-fold (0.01 log units) above what was measured, and the stated range covers the measured number.
By their numbers in this assay, from the lowest: compound 2; then compound 1; then compound 4; then compound 3.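

In this assay the exchange of 1,2,3,4-tetrahydronaphthalen-5-yl for 1H-indol-2-yl gives a 4.8-fold lower number from compound 3 to compound 4 (0.68 log units; beyond the scatter) and shows that a group of two fused rings on this carbonyl carbon need not cost as much as compound 3 suggested. Compound 4 still does not match the single-ring amides, with a 6.3-fold higher number from compound 2 to compound 4 (0.80 log units; beyond the scatter) and a 2.0-fold higher number from compound 1 to compound 4 (0.31 log units; beyond the scatter) in this assay as the remaining gaps. Nothing here explains these differences. Still open, from the compounds shown here alone, is how 1-methyl-1H-indol-2-yl, without the indole hydrogen, would read here. Going by these compounds, an unsubstituted phenyl or a pyridinyl group on this carbonyl carbon is also open.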